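The source may report more compounds than this note shows. Statements on the series, on what has been measured and on what is new or still open speak of the compounds shown alone.

Measured compounds:
Compound 1 `N#Cc1c(Nc2ccccc2F)nc(SCc2cn(Cc3ccccc3Cl)nn2)nc1-c1ccccc1`: 23000 nM
Compound 2 `N#Cc1c(Nc2ccc(F)cc2)nc(SCc2cn(Cc3ccccc3Cl)nn2)nc1-c1ccccc1`: 25800 nM

Both compounds were tested in a functional assay on ECa-109 cells (Homo sapiens) for inhibition, read by MTT assay, with a stated time of 72 h; on this read-out lower numbers stand for stronger inhibition and higher numbers for weaker inhibition. Compound 2 gives 25800 nM, the larger of the two numbers, while compound 1 gives 23000 nM; the step of a 1.1-fold higher number from compound 1 to compound 2 (0.05 log units; within the scatter) lies within the scatter, so the two compounds cannot be told apart. Within the data shown here, the only measured step, 4-fluorophenyl in place of 2-fluorophenyl on the nitrogen, thus produced no change that can be trusted.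

Compound 3 `N#Cc1c(Nc2ccccc2)nc(SCc2cn(Cc3ccccc3Cl)nn2)nc1-c1ccccc1` has not yet been measured. It differs from compound 2 by hydrogen in place of fluoro on an aromatic carbon, para to a large group. Among the measured compounds shown here, no measured step removes a fluoro altogether; the one step available, a 1.1-fold higher number from compound 1 to compound 2 (0.05 log units; within the scatter), only relocates it, and that relocation stayed within the scatter. For compound 3 in this assay the expected step is therefore a 1.0-fold lower number from compound 2 to compound 3 (0.01 log units; within the scatter), a change not expected to exceed the scatter. The estimated value for compound 3 is 25000 nM, with a likely range from 12000 nM to 52000 nM.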

Compound 3, half-maximal inhibitory concentration: > 64000 nM
Compound 3 gave a limit, no number; the forecaster's own chance of this, stated with the estimate: 10%; at least 2.5-fold (0.40 log units) between middle value and limit.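

The earlier pair showed only that the fluoro could sit in either of two places on the anilino ring without a change beyond the scatter, which said nothing about whether the fluoro was needed at all. This result shows that its presence matters: in this assay, hydrogen in place of fluoro gives an at least 2.4-fold higher number from compound 2 to compound 3 (0.39 log units; beyond the scatter), and the same change counted from the other fluorinated compound gives an at least 2.7-fold higher number from compound 1 to compound 3 (0.44 log units; beyond the scatter), so the compound without fluoro inhibits more weakly than either compound with one. The reading for compound 3 is a limit and not a number, so each of these steps is a smallest size: the limit of > 64000 nM in this assay, at which 1 of the 3 values shown sits.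

The compounds shown leave open whether this difference is special to fluoro or would also appear with another group on the same ring, such as chloro, methyl, methoxy or an amine. The rest of the molecule is the same in all three compounds, so they also cannot tell whether the fluoro would matter as much on a different core.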